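Amino in Place of Methoxy in a Small Set

A few compounds are considered here, and "the series" means these few. Any claim that something is new, unique, unknown or untested is made for them only; others in the source may bear on it.

The set comprises three measured compounds and one that awaits measurement. Compound 1 `Nc1ccccc1/C=C/c1ccccc1O`, compound 2 `COc1ccccc1/C=C/c1ccccc1O` and compound 3 `COc1ccc(/C=C/c2ccccc2O)cc1` were tested in a functional assay on HT-29 cells (Homo sapiens) for inhibition, read by MTT assay, with a stated time of 2 days; a lower number here means a stronger inhibitor, a higher number a weaker inhibitor. In this assay compound 1 gives 36 ug/mL, compound 2 gives 23 ug/mL, and compound 3 gives 10 ug/mL, the lowest of the three numbers.

Compound 2 and compound 1 differ in a single place: amino in place of methoxy on an aromatic carbon. The change made a step of a 1.6-fold higher number from compound 2 to compound 1 (0.19 log units; within the scatter), which lies within the scatter, so the two values cannot be put in order. Compound 3 and compound 2 are built from the same atoms joined differently; the difference between the two cores is not broken down here.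

Compound 4 `Nc1ccc(/C=C/c2ccccc2O)cc1` has not been measured. It stands to compound 3 as compound 1 stands to compound 2: amino in place of methoxy on an aromatic carbon. The two places are not the same word for word, the group in compound 1 being ortho to a group of 9 heavy atoms and the group in compound 4 being para to a group of 9 heavy atoms, so the two changes are the same kind of change rather than the same change. Among the measured compounds shown here, the only precedent is the step of a 1.6-fold higher number from compound 2 to compound 1 (0.19 log units; within the scatter), which was within the scatter. Resting on that precedent, the step of a 1.5-fold higher number from compound 3 to compound 4 (0.18 log units; within the scatter) is expected to be small. Compound 4 is therefore estimated at 15 ug/mL, with a likely range from 7 ug/mL to 35 ug/mL.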

Compound 4, half-maximal inhibitory concentration: 37 ug/mL
Beside the measured number, compound 4's estimate is 2.5-fold (0.39 log units) below it; measured number above the stated range.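

In this assay, amino in place of methoxy on an aromatic carbon, para to a group of 9 heavy atoms, gave a 3.7-fold higher number from compound 3 to compound 4 (0.57 log units; beyond the scatter), a modest step that lies beyond the scatter, whereas the same kind of change on the other core stayed within it. Even so, the two steps cannot be told apart, so the series gives no sign that the core or the place of the group alters what this change does: the same change on two cores in this assay, a 1.6-fold higher number (0.19 log units; within the scatter) from compound 2 to compound 1 and a 3.7-fold higher number (0.57 log units; beyond the scatter) from compound 3 to compound 4, 2.4-fold (0.37 log units) apart, within the scatter of two such steps. Among the compounds shown here, this does not show that the change carries over unaltered either, since the comparison rests on only two pairs, the group sits in a different place on each core, and the earlier step alone gave no order between its two compounds, so a reader could not have relied on a small step recurring.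

The compounds shown leave open how other groups in the same place, such as a dimethylamino group, an ethoxy group or a fluorine, would compare with amino and methoxy on either core. They also leave open whether the step from methoxy to amino would keep its size in cell lines other than the one tested here.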